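From butoxy to (thiophen-2-yl)oxy on a shared core

The source may hold more compounds than are shown below. What is called first, only, known or untested is meant among the compounds shown, and "the series" means these compounds.

compound 1 `CCCCOC1=CC(=O)c2ccccc2C1=O` gives 27000 nM
compound 2 `O=C1C=CC(=O)c2c(Oc3cccs3)cccc21` gives 6230 nM
compound 3 `CCOc1ccc2c(c1)C(=O)C=CC2=O` gives 21400 nM

In a functional assay on KB cells (Homo sapiens) for cytotoxicity (a higher number here means a weaker inhibitor, a lower number a stronger inhibitor), compound 1 stands level with compound 3, within the scatter, while compound 2 has a lower number, beyond the scatter.

Compound 4 `O=C1C=C(Oc2cccs2)C(=O)c2ccccc21` has not yet been measured. It differs from compound 1 by a single swap, thiophen-2-yl in place of butyl on an oxygen on an unsaturated carbon.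

Within the data shown here, no measured pair isolates this swap. Among the measured compounds shown here, the only guide is compound 2, which gives 6230 nM while also carrying (thiophen-2-yl)oxy, though not in the place it takes in compound 4. A moderate move towards a lower number, meaning a stronger inhibitor, therefore seems likely. The expected size of a 2.7-fold lower number from compound 1 to compound 4 (0.43 log units; beyond the scatter) is only a rough estimate, resting on this single indirect comparison. For compound 4 the estimated value is 10000 nM with an expected span of 3500 nM to 27000 nM as the likely range.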

Compound 4, half-maximal inhibitory concentration: 41500 nM
Estimate against measurement, compound 4: 4.2-fold (0.62 log units) below; the whole stated range lies below it.
By their numbers in this assay, from the lowest: compound 2; then compounds 3, 1 and 4 (each within the scatter of the next).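

At this oxygen on an unsaturated carbon, putting thiophen-2-yl in place of butyl gives, in this assay, a 1.5-fold higher number from compound 1 to compound 4 (0.19 log units; within the scatter), so the aromatic ring and the open chain leave the two compounds level. Carrying (thiophen-2-yl)oxy is therefore not enough on its own for a number like that of compound 2 at 6230 nM, since compound 4 holds the same group in another place and gives 41500 nM. No measurement shown offers a reason for this result.

Still open, from the compounds shown here alone, is whether an amine or a carboxylic acid on a chain at this oxygen would give a number clearly apart from compound 1. Also open, going by these compounds, is whether butoxy, placed where compound 2 carries its (thiophen-2-yl)oxy, would match compound 2, which would separate the effect of place from that of group.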